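The compounds below may be only part of what the source reports. "The series", "measured", "known", "first", "only" and "open" are said of these compounds alone.

Of the compounds shown here, three sharing one core have been measured in a physicochemical assay for solubility, at pH 7.4; a higher number here means a more soluble compound, a lower number a less soluble compound. Compound 1 `COc1ccc(NC(=O)Nc2cc(C)nc3ccccc23)cc1` gives 19800 nM, the highest of the three numbers. Compound 2 `COc1ccc(NC(=O)Nc2cc(C)nc3ccccc23)cc1F` gives 2700 nM in this assay, and compound 3 `COc1ccc(NC(=O)Nc2cc(C)nc3ccccc23)cc1Cl` gives 400 nM. Both steps away from compound 1 run downward: a 7.3-fold lower number from compound 1 to compound 2 (0.87 log units; beyond the scatter) and a 50-fold lower number from compound 1 to compound 3 (1.69 log units; beyond the scatter). Between the two halogenated compounds, a 6.8-fold lower number from compound 2 to compound 3 (0.83 log units; beyond the scatter).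

Compound 4 `CCc1ccc(NC(=O)Nc2cc(C)nc3ccccc23)cc1` has not yet been measured in this assay. It differs from compound 1 in one place: ethyl in place of methoxy on an aromatic carbon. Among the measured compounds shown here, none of the measured steps bears directly on this change. Each of them introduces fluoro or chloro in place of hydrogen, or exchanges one halogen for the other, while the methoxy group is retained in compounds 1, 2 and 3. For the measured compounds named here, the measured compounds therefore establish only that compound 1 is the most soluble of the three, and that every alteration to it so far has lowered the number; the size of the step from methoxy to ethyl has no close precedent in this set. A modest downward step is expected, a 2.5-fold lower number from compound 1 to compound 4 (0.39 log units; beyond the scatter), smaller than the step from compound 1 to compound 3. Compound 4 is accordingly estimated to give 8000 nM in this assay, with a range from 2500 nM to 25000 nM.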

Compound 4, solubility: 3300 nM
The estimate for compound 4 lay 2.4-fold (0.38 log units) above the measured number, within the range that was stated.
By their numbers in this assay, from the lowest: compound 3; then compounds 2 and 4 (each within the scatter of the next); then compound 1.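

Among the compounds shown here, exchanging methoxy for ethyl on an aromatic carbon para to a large group gives, in this assay, a 6.0-fold lower number from compound 1 to compound 4 (0.78 log units; beyond the scatter) and is the first reading of a change to the methoxy group itself, since the halogen steps all retained it. The exchange leaves the count at 2 heavy atoms and replaces an oxygen with a carbon, so the number at this position responds to a change of atom type without any change in the size of the count, and compound 1 stays highest of the four compounds, with every change away from it so far lowering the number. No measurement shown here accounts for this step.

Going by these compounds, whether another oxygen-bearing group at this position, such as a hydroxyl or a longer ether chain like ethoxy, would keep the number nearer that of compound 1 remains open. So does the outcome for an amine, a carboxylic acid or a morpholine ring at this same place, and for a longer carbon chain such as propyl.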